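The compounds below may be only part of what the source reports. "The series", "measured", "known", "first", "only" and "open" are said of these compounds alone.

Compound 1 `Cc1cc(S(N)(=O)=O)ccc1NC(=O)COc1ccc(Cl)cc1NC(=O)c1cccc(Cl)c1`: 59700 nM
Compound 2 `Cc1cc(S(N)(=O)=O)ccc1NC(=O)COc1ccc(Cl)cc1NC(=O)c1ccc(Cl)cc1Cl`: 61100 nM
Compound 3 `Cc1cc(S(N)(=O)=O)ccc1NC(=O)COc1ccc(Cl)cc1NC(=O)c1cc(Cl)cc(C#N)c1`: 131000 nM

In a functional assay on C8166 cells (Homo sapiens) for cytotoxicity, read by MTT assay (a lower number here means that less compound is tolerated, a higher number that more compound is tolerated), compound 3 stands highest of the three, at 131000 nM. Compound 4 `Cc1cc(S(N)(=O)=O)ccc1NC(=O)COc1ccc(Cl)cc1NC(=O)c1ccc2ccccc2c1` has naphthalen-2-yl in place of 3-chloro-5-cyanophenyl on a carbonyl carbon, so the cyano group is lost. Among the measured compounds shown here, three measured steps bear on this. Exchanging one chlorinated aryl group for another stayed within the scatter: a 1.0-fold higher number from compound 1 to compound 2 (0.01 log units; within the scatter). The two steps that brought in cyano were modest: a 2.2-fold higher number from compound 1 to compound 3 (0.34 log units; beyond the scatter) and a 2.1-fold higher number from compound 2 to compound 3 (0.33 log units; beyond the scatter). On these data alone, compound 4 lacks cyano, so a return towards the values without it is expected, although naphthalen-2-yl itself is untested here. The expected change is modest, a 2.0-fold lower number from compound 3 to compound 4 (0.30 log units; within the scatter). Compound 4 is estimated at 65000 nM, with an expected range of 30000 nM to 130000 nM.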

Compound 4, half-maximal cytotoxic concentration: 37600 nM
Compound 4: the middle estimate sits 1.7-fold (0.24 log units) above what was measured, within the range that was stated.
By their numbers in this assay, from the lowest: compounds 4, 1 and 2 (each within the scatter of the next); then compound 3.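

In this assay naphthalen-2-yl on the carbonyl carbon does not keep the number of compound 3 (a 3.5-fold lower number from compound 3 to compound 4 (0.54 log units; beyond the scatter)). Set against the chlorinated aryl groups without cyano, the same group gives no change beyond the scatter (a 1.6-fold lower number from compound 2 to compound 4 (0.21 log units; within the scatter)) and (a 1.6-fold lower number from compound 1 to compound 4 (0.20 log units; within the scatter)), so among these four compounds only compound 3, the one carrying cyano, stands apart. Nothing measured here explains this difference. On these data alone, whether cyano alone sets compound 3 apart remains open, as does how an amine or a carboxylic acid at this position would read.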